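This account rests on a few compounds, and the source may have more. Where it says the series, first, only, none or still open, it means among the compounds named here.

Compound 1 `CC(=O)N[C@@H]1CCC[C@H](C(=O)Nc2cc(-c3cnn4c3CCC4)c(Cl)cn2)C1`: < 3 mL.min-1.g-1 (a limit)
Compound 2 `CC(=O)N[C@@H]1CCC[C@H](C(=O)Nc2cc(-c3cnc4n3CCC4)c(Cl)cn2)C1`: 9.7 mL.min-1.g-1
Compound 3 `CC(=O)N[C@@H]1CCC[C@H](C(=O)Nc2cc(-c3cnn4c3CN(C)CC4)c(Cl)cn2)C1`: < 3 mL.min-1.g-1 (a limit)

In an ADME assay on microsomes from liver (Homo sapiens) for metabolic stability (on this read-out lower numbers stand for slow clearance and higher numbers for fast clearance), compound 3 gives < 3 mL.min-1.g-1, which is a limit of the assay and not a number. Compound 4 `CC(=O)N[C@@H]1CCC[C@H](C(=O)Nc2cc(-c3cnn4c3CC(C)(C)C4)c(Cl)cn2)C1` differs from it by one change: a group of 10 heavy atoms (8 carbon, 2 nitrogen; one five-membered non-aromatic ring with 1 hetero atom, one five-membered aromatic ring with 2 hetero atoms) in place of a group of 10 heavy atoms (7 carbon, 3 nitrogen; one five-membered aromatic ring with 2 hetero atoms, one six-membered non-aromatic ring with 2 hetero atoms), on an aromatic carbon. The entering group has the same ring types as the groups in compound 1 and compound 2, yet those two compounds are separated by an at least 3.2-fold higher number from compound 1 to compound 2 (0.50 log units; beyond the scatter). The comparison gives a step that the two limits leave unreadable from compound 1 to compound 3, whereas it gives an at least 3.2-fold lower number from compound 2 to compound 3 (0.50 log units; beyond the scatter). In this assay, a small rise is therefore expected, possibly none beyond the scatter. The expected change is an at least 1.1-fold higher number from compound 3 to compound 4 (0.06 log units; that floor lies within the scatter). The estimate for compound 4 is 3.5 mL.min-1.g-1, with an expected range from 2 mL.min-1.g-1 to 9 mL.min-1.g-1.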

Compound 4, intrinsic clearance in microsomes: 50 mL.min-1.g-1
Estimate against measurement, compound 4: 14-fold (1.15 log units) below, outside the stated range (above it).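

On the aromatic carbon ortho to a chloro group, ring types alone do not set the read-out in this assay: the entering group has the same ring types as the groups in compound 1 and compound 2, yet the data give an at least 16-fold higher number from compound 1 to compound 4 (1.22 log units; beyond the scatter) and a 5.2-fold higher number from compound 2 to compound 4 (0.71 log units; beyond the scatter). The change from the six-membered non-aromatic ring gives an at least 16-fold higher number from compound 3 to compound 4 (1.22 log units; beyond the scatter). Two of these steps are floors, not full sizes: the limit of < 3 mL.min-1.g-1 in this assay, at which 2 of the 4 values shown sit.

The compounds shown leave open whether fluorine or a hydroxyl group on the five-membered non-aromatic ring would keep the number high. As far as these compounds go, how far compound 1 and compound 3 lie under their limit also stays unknown.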